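Methyl to nitro on the benzamide arm of compound 3

The compounds below may be only part of what the source reports. "The series", "measured", "known", "first", "only" and "open" are said of these compounds alone.

For the measured compounds named here, compound 3 `Cc1ccc(C(=O)Nc2cccc(NC(=O)COc3ccc4c(=O)ccoc4c3)c2)cc1` is the higher of the two numbers so far in an assay on isolated protein for inhibition of Rho-associated protein kinase 1 (Homo sapiens), read by scintillation counting, radiometric assay and 33P incorporation, with a stated time of 40 min, in the presence of a further agent that is not named here; on this read-out higher numbers stand for weaker inhibition and lower numbers for stronger inhibition. Its nearest neighbour is compound 2 `CN(C)c1ccc(C(=O)Nc2cccc(NC(=O)COc3ccc4c(c3)OCCC4=O)c2)cc1`, which in this assay gives 144 nM, while compound 3 gives 183 nM; the gap between the two lies within the scatter, so no order can be read from it. Compound 1 `CN(C)c1ccc(C(=O)Nc2cccc(NC(=O)COc3ccc4c(c3)NC(=O)CC4)c2)cc1` reaches only a limit of this assay, > 10000 nM, with no number behind it (the limit of > 10000 nM in this assay, at which 1 of the 3 values shown sits).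

Going by the values given here, the only measured step, an at least 69-fold lower number from compound 1 to compound 2 (1.84 log units; beyond the scatter), changes the ring system carried on the oxygen on a saturated carbon. It tells nothing about the benzamide end, which is where compound 4 `O=C(COc1ccc2c(=O)ccoc2c1)Nc1cccc(NC(=O)c2ccc([N+](=O)[O-])cc2)c1` departs from compound 3: nitro in place of methyl on an aromatic carbon. Among the compounds with values here, no step among the measured compounds touches this aromatic carbon, so there is no ground for expecting a change beyond the scatter in either direction, and the expected step of a 1.0-fold lower number from compound 3 to compound 4 (0.01 log units; within the scatter) is set at no change.

Within the data shown here, compound 4 is therefore expected to give about 180 nM in this assay, with a plausible range from 55 nM to 600 nM that is widened because the change has no measured counterpart here.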

Compound 4, half-maximal inhibitory concentration: 67 nM
Compound 4: the middle estimate sits 2.7-fold (0.43 log units) above what was measured; the range from low to high includes it.
By their numbers in this assay, from the lowest: compound 4; then compounds 2 and 3 (each within the scatter of the next). At a limit, above all of these: compound 1.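

In this assay, for the compounds shown here, the first measured change at the benzamide end, a 2.7-fold lower number from compound 3 to compound 4 (0.44 log units; beyond the scatter), shows that the group on this aromatic carbon is not without consequence. The step is smaller than an at least 69-fold lower number from compound 1 to compound 2 (1.84 log units; beyond the scatter), which came from a change in the ring system, but it shows that the place para to a large group on the six-membered aromatic ring of carbon only also responds to substitution, and that nitro, with its 2 hydrogen-bond acceptors, is accepted there in place of methyl with no loss of inhibition. Nothing shown here gives a measured property of either group that bears on this step.

A single pair cannot tell whether the lower number belongs to nitro in particular or would follow from other replacements of methyl, and a nitrile, a carboxylic acid or an amine on the same carbon would begin to separate those readings. From the compounds shown here alone, it also remains open whether the same exchange would give a step of similar size on the core of compound 2 or on the core of compound 1, since here it is seen on the core of compound 3 alone.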